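From an Alkyne-Linked Thiophene to a Direct Chlorophenyl

The source may report more compounds than this note shows. Statements on the series, on what has been measured and on what is new or still open speak of the compounds shown alone.

Three measured compounds share one core and differ only in the group on one aromatic carbon. Compound 1 `CCCC#Cc1cc([C@@H]2O[C@H](CO)[C@@H](O)[C@H]2O)n2ncnc(N)c12` bears propyl on a triple-bonded carbon; in a functional assay on HL-60 cells (Homo sapiens) for antiproliferative activity, with a stated time of 72 h (a higher number here means a weaker inhibitor, a lower number a stronger inhibitor), compound 1 gives 200 nM. Compound 2 `Nc1ncnn2c([C@@H]3O[C@H](CO)[C@@H](O)[C@H]3O)cc(C#Cc3ccc(F)cc3)c12` carries 4-fluorophenyl on that triple-bonded carbon, and compound 3 `Nc1ncnn2c([C@@H]3O[C@H](CO)[C@@H](O)[C@H]3O)cc(C#Cc3cccs3)c12` carries thiophen-2-yl there. For compound 2 this assay reports only a limit, > 100000 nM. For compound 3 this assay likewise reports only a limit, > 100000 nM. Both moves from propyl to an aromatic group are large: an at least 500-fold higher number from compound 1 to compound 2 (2.69 log units; beyond the scatter) and an at least 500-fold higher number from compound 1 to compound 3 (2.69 log units; beyond the scatter); between the two aromatic groups, a step that the two limits leave unreadable from compound 2 to compound 3. Compound 3 therefore stands at the limit of > 100000 nM in this assay, at which 2 of the 3 values shown sit. Compound 4 `Nc1ncnn2c([C@@H]3O[C@H](CO)[C@@H](O)[C@H]3O)cc(-c3ccc(Cl)cc3)c12` differs from compound 3 by 4-chlorophenyl in place of 2-(thiophen-2-yl)ethynyl on an aromatic carbon. Going by the values given here, no measured step bears directly on this change, which removes the triple bond rather than exchanging what hangs on it; the only guidance is that both aromatic groups on the triple-bonded carbon gave limits. Compound 4 is expected to remain weak, with an at least 1.6-fold lower number from compound 3 to compound 4 (0.22 log units; that floor lies within the scatter) carrying little confidence. The estimated value for compound 4 is 60000 nM, within 5000 nM to 300000 nM.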

Compound 4, half-maximal inhibitory concentration: 37900 nM
Beside the measured number, compound 4's estimate is 1.6-fold (0.20 log units) above it, and the stated range covers the measured number.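

Going by these compounds alone, replacing the whole alkyne-linked group with 4-chlorophenyl gives the first aromatic group here with a readable number in this assay, with an at least 2.6-fold lower number from compound 3 to compound 4 (0.42 log units; beyond the scatter) and an at least 2.6-fold lower number from compound 2 to compound 4 (0.42 log units; beyond the scatter). An aromatic ring at this position therefore need not sit at the limit once the triple bond is gone, yet the recovery is only partial, with a 190-fold higher number from compound 1 to compound 4 (2.28 log units; beyond the scatter) leaving compound 1 with its pent-1-yn-1-yl group far stronger. Compound 2 and compound 3 remain limits, not numbers: the limit of > 100000 nM in this assay, at which 2 of the 4 values shown sit.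

Whether the change in compound 4 comes from losing the triple bond or from the chlorine-bearing ring stays open among the compounds shown. Also open, going by these compounds, is how a butyl chain or an amine joined directly to this aromatic carbon would compare with 4-chlorophenyl and with pent-1-yn-1-yl.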